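Chloro for fluoro on the difluorophenyl group of compound 1

The source may hold more compounds than are shown below. What is called first, only, known or untested is meant among the compounds shown, and "the series" means these compounds.

Compound 1 `CC[C@H](NC(C)=O)c1cc(Cl)ccc1C1CCN(C(=O)[C@H]2CN(C(C)(C)C)C[C@@H]2c2ccc(F)cc2F)CC1` gives 640 nM in an assay on CHO cells for displacement of a labelled ligand from Melanocortin receptor 4 (Homo sapiens) (on this read-out higher numbers stand for weaker inhibition and lower numbers for stronger inhibition), the highest of the three numbers in hand. Compound 2 `CC[C@H](NC(C)=O)c1cc(Cl)ccc1C1CCN(C(=O)[C@@H]2CN(C(C)(C)C)C[C@H]2c2ccc(F)cc2F)CC1` gives 70 nM, a step of a 9.1-fold lower number from compound 1 to compound 2 (0.96 log units; beyond the scatter) that rests on (the fact that compounds 1 and 2 differ only in the configuration as drawn). Compound 3 `CC[C@H](NC(C)=O)c1cc(Cl)ccc1C1CCN(C(=O)[C@@H]2CN(C(C)(C)C)C[C@H]2c2ccc(F)cc2Cl)CC1` gives 216 nM, a step of a 3.1-fold higher number from compound 2 to compound 3 (0.49 log units; beyond the scatter). Compound 4 `CC[C@H](NC(C)=O)c1cc(Cl)ccc1C1CCN(C(=O)[C@H]2CN(C(C)(C)C)C[C@@H]2c2ccc(Cl)cc2F)CC1` is not yet measured; it differs from compound 1 by chloro in place of fluoro on an aromatic carbon. Among the compounds with values here, the only comparable measured step is the chloro-for-fluoro swap from compound 2 to compound 3 on the same difluorophenyl group, which raised the number modestly; a shift of similar size and direction is expected here, a 2.3-fold higher number from compound 1 to compound 4 (0.37 log units; beyond the scatter). Compound 4 is thus estimated at 1500 nM, within 600 nM to 4000 nM.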

Compound 4, half-maximal inhibitory concentration: 13.2 nM
Estimate against measurement, compound 4: 110-fold (2.06 log units) above; the whole stated range lies above it.
By their numbers in this assay, from the lowest: compound 4; then compound 2; then compound 3; then compound 1.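

In this assay, chloro in place of fluoro para to a large group gives a 48-fold lower number from compound 1 to compound 4 (1.69 log units; beyond the scatter), so this swap can strengthen inhibition by a large step on the configuration of compound 1. The effect of chloro for fluoro has no single direction in this series: the same change on two cores in this assay, a 3.1-fold higher number (0.49 log units; beyond the scatter) from compound 2 to compound 3 and a 48-fold lower number (1.69 log units; beyond the scatter) from compound 1 to compound 4, 150-fold (2.17 log units) apart, beyond the scatter of two such steps In compound 3 the chloro replaces the other fluoro of the ring, so the two steps differ in place as well as in configuration.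

Open, on these data alone, is how the 4-chloro-2-fluorophenyl group behaves on the configuration of compound 2, which would separate these two differences. Also open, as far as these compounds go, is whether bromo or methyl at this place follows chloro.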